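The compounds below may be only part of what the source reports. "The series", "measured", "known", "first", "only" and "open" are said of these compounds alone.

Of the compounds shown here, three built on one shared core have so far been tested in a functional assay (trachea) with Rattus norvegicus as the target; a higher number here means a more potent compound, by a factor of ten per unit of this negative logarithm, a lower number a less potent compound. Compound 1 `CC1(C)C=C(n2ccccc2=O)c2cc(C(=O)c3cccs3)ccc2O1` gives 5.84. Compound 2 `CC1(C)C=C(n2ccccc2=O)c2cc(OCC(=O)c3ccccc3)ccc2O1` gives 4.69, and compound 3 `CC1(C)C=C(n2ccccc2=O)c2cc(OC(=O)Nc3ccccc3C(F)(F)F)ccc2O1` gives 5.19. Compound 1 therefore stands highest of the three numbers; compound 3 lies nearest to it, with a gap that is beyond the usual scatter, and compound 2 lies furthest away, again beyond the scatter.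

Compound 4 `CC1(C)C=C(n2ccccc2=O)c2cc(C(=N)S)ccc2O1` has not yet been measured. It differs from compound 1 in one place: a group of 3 heavy atoms (1 carbon, 1 nitrogen, 1 sulfur; no ring) in place of a group of 7 heavy atoms (5 carbon, 1 oxygen, 1 sulfur; one five-membered aromatic ring with 1 hetero atom), on an aromatic carbon. None of the three measured compounds shows this exchange on its own, so the size of the step cannot be read from them directly. What the numbers do show is that compound 1, carrying the (thiophen-2-yl)carbonyl with its five-membered aromatic ring, holds the top value of 5.84; replacing that group by one of only 3 heavy atoms with no ring is a large change, and a loss of potency is expected rather than a gain. The step from compound 1 to compound 4 in this assay is expected to be a number 0.84 log units lower from compound 1 to compound 4 (beyond the scatter). Compound 4 is accordingly estimated at 5, with a likely range from 4.3 to 5.7.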

Compound 4, logarithm of the reciprocal of the active concentration, log(1/C): 5.96
Compound 4: middle estimate off by 0.96 log units, on the low side; measured number outside the range, above it.
By their numbers in this assay, from the lowest: compound 2; then compound 3; then compounds 1 and 4 (each within the scatter of the next).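

In this assay, among the compounds shown here, exchanging the (thiophen-2-yl)carbonyl on this aromatic carbon for a group of 3 heavy atoms with no ring gives a step of a number 0.12 log units higher from compound 1 to compound 4 (within the scatter). For the compounds shown here, this is the first pair in the set that differs in only one place, and it shows that at this position the five-membered aromatic ring and most of the bulk of the group can go without the number moving beyond the scatter, even though the entering group has 2 hydrogen-bond donors and the leaving group has 0. Nothing available here explains why two such different groups read alike in this assay.

Which atoms of the entering group matter remains open, and a single pair cannot separate the loss of the ring from the gain of the donors. A carboxamide, a nitrile, a carboxylic acid or a longer chain on the same aromatic carbon would show whether this position accepts many different groups or only a few.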